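Methoxy step repeated on the phenyl-bearing core

The compounds below may be only part of what the source reports. "The series", "measured", "known", "first", "only" and "open" are said of these compounds alone.

Three compounds of one series are in hand. Compound 1 `C=CCn1c(SCC(=O)c2ccccc2)nnc1-c1ccccc1` is the parent; compound 2 `C=CCn1c(SCC(=O)c2ccccc2)nnc1-c1ccc(OC)cc1` and compound 3 `O=C(CSc1nnc(-c2ccccc2)n1-c1ccccc1)c1ccccc1` each alter it in a single place. All three were run in a functional assay on the whole organism (strain albino) for inhibition, with Rattus norvegicus as the target, read by paw edema, with a stated time of 4 h, at a dose of 0.28 mmol/kg by the oral route; a lower number here means less inhibition, a higher number more inhibition at the dose given (going by the name of the read-out). Compound 1 gives 66%, compound 2 gives 67% and compound 3 gives 68% in this assay. The three numbers sit close together, and no order among them can be claimed.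

The change from compound 1 to compound 2 is methoxy in place of hydrogen on an aromatic carbon, and it made a number 1 percentage points higher from compound 1 to compound 2 (within the scatter). The two cores differ by phenyl in place of allyl on an aromatic nitrogen, a change that made a number 2 percentage points higher from compound 1 to compound 3 (within the scatter).

Compound 4 `COc1ccc(-c2nnc(SCC(=O)c3ccccc3)n2-c2ccccc2)cc1` has not been measured. It differs from compound 3 by methoxy in place of hydrogen on an aromatic carbon. The surroundings of the site are described in the same words for this change and for the change from compound 1 to compound 2, so it is the same change, now made on the core of compound 3 instead of the core of compound 1.

The step from compound 3 to compound 4 in this assay is expected to be a number 1 percentage points higher from compound 3 to compound 4 (within the scatter), set beside a number 1 percentage points higher from compound 1 to compound 2 (within the scatter), and this rests on that single earlier instance of the change together with the value of compound 3 of 68%. Compound 4 is therefore estimated at 69%, with a likely range from 58% to 78%.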

Compound 4, a percentage reported as inhibition, in the whole organism at one dose (the size of the read-out at that dose, not a potency): 68%
Compound 4: the middle estimate sits 1 percentage points above what was measured; the measured number falls inside the stated range.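

In this assay, methoxy in place of hydrogen on the core of compound 3 gives no change at the digits printed from compound 3 to compound 4 (within the scatter), and set against the same change on the core of compound 1 the two steps do not differ: the same change on two cores in this assay, a number 1 percentage points higher (within the scatter) from compound 1 to compound 2 and no change at the digits printed (within the scatter) from compound 3 to compound 4, 1 percentage points apart, within the scatter of two such steps

Phenyl in place of allyl on the aromatic nitrogen, now read on the methoxy-bearing pair, gives a number 1 percentage points higher from compound 2 to compound 4 (within the scatter), and this step also agrees with its earlier instance: the same change on two cores in this assay, a number 2 percentage points higher (within the scatter) from compound 1 to compound 3 and a number 1 percentage points higher (within the scatter) from compound 2 to compound 4, 1 percentage points apart, within the scatter of two such steps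

Both changes therefore carry across the two cores shown without any detectable difference, but every step involved lies within the scatter, so this is agreement between steps that cannot be told from no step at all: it does not show that either change has an effect of its own, nor that a change with a real effect would carry from one core to the other in the same way.

Still open, from the compounds shown here alone, is whether an amine or a carboxylic acid in place of methoxy on that aromatic carbon, or a longer chain in place of allyl on the aromatic nitrogen, would move the number beyond the scatter. The phenyl ketone end is the same in all four compounds, so these compounds say nothing about a change there, and a reading at one dose gives no potency for any of them.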